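The source may hold more compounds than are shown below. What is called first, only, known or untested is meant among the compounds shown, and "the series" means these compounds.

Compound 1 `Cc1ccc(CS(=O)(=O)/C(=C/c2cccc(Cl)c2Cl)C(=O)c2ccc(Cl)cc2)cc1` and compound 2 `O=C(/C(=C\c1c[nH]c2ccccc12)SCc1ccc(F)cc1)c1ccc(Cl)cc1` were both examined in a functional assay on DU-145 cells (Homo sapiens) for inhibition, read by trypan blue exclusion, with a stated time of 96 h; on this read-out higher numbers stand for weaker inhibition of growth and lower numbers for stronger inhibition of growth. In this assay compound 1 gives 1000 nM. In this assay compound 2 gives 1000 nM. On these numbers compound 1 stands level with compound 2 at the digits shown; its nearest neighbour is compound 2, and the two do not differ beyond the scatter. Compound 3 `Cc1ccc(CS(=O)(=O)/C(=C/c2ccc(Cl)cc2)C(=O)c2ccc(Cl)cc2)cc1` has not yet been measured in this assay. It differs from compound 1 in a single place: 4-chlorophenyl in place of 2,3-dichlorophenyl on a double-bonded chain carbon bound to a double-bonded chain carbon. Going by the values given here, no step between two measured compounds that differ in one place is available, so nothing among the measured compounds fixes the size of this change. The expected step of a 1.5-fold higher number from compound 1 to compound 3 (0.18 log units; within the scatter) is small, toward weaker inhibition if anything, and not beyond the scatter. Compound 3 is therefore expected to give 1500 nM, with a range from 500 nM to 5000 nM.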

Compound 3, concentration for 50% growth inhibition: 25000 nM
For compound 3 the middle estimate is 17-fold (1.22 log units) below the measured one; measured number above the stated range.
By their numbers in this assay, from the lowest: compounds 1 and 2 (each within the scatter of the next); then compound 3.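

In this assay, 4-chlorophenyl in place of 2,3-dichlorophenyl gives a 25-fold higher number from compound 1 to compound 3 (1.40 log units; beyond the scatter), the first single change whose size can be read among these compounds. It shows that this place, on a double-bonded chain carbon bound to a double-bonded chain carbon, is sensitive to the chlorine substitution of the phenyl ring, although both groups are chlorinated phenyl rings with the same ring and no hydrogen-bond donors or acceptors. Nothing measured here explains the size of this step.

Going by these compounds alone, the one step does not separate the effect of the chlorine that is lost from that of the altered chlorine pattern. It also leaves open how a 2-chlorophenyl, a 3-chlorophenyl or a phenyl ring bearing an amine or a carboxylic acid would stand at this place.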